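The compounds below may be only part of what the source reports. "The series", "measured", "known", "first", "only" and "open" are said of these compounds alone.

Measured compounds:
Compound 1, `Nc1ccccc1NC(=O)/C=C/c1ccc(CSc2ccc(Cl)cc2)cc1`: 16.5%
Compound 2, `Nc1ccccc1NC(=O)/C=C/c1ccc(CSc2ccc(F)cc2)cc1`: 15.4%
Compound 3, `Nc1ccccc1NC(=O)c1ccc(CSc2ccc(F)cc2)cc1`: 81.9%

In a functional assay on SMMC-7721 cells (Homo sapiens) for inhibition, read by CCK-8 assay, with a stated time of 72 h, tested at 8 uM (on this read-out lower numbers stand for less inhibition of growth and higher numbers for more inhibition of growth at the one concentration tested), compound 2 gives 15.4% and compound 1 gives 16.5%. These two share one core and differ by chloro in place of fluoro on an aromatic carbon. That change made a step of a number 1.1 percentage points higher from compound 2 to compound 1 (within the scatter), so the two numbers cannot be told apart. Compound 3 in this assay gives 81.9%, the highest of the three measured numbers, and its gap to compound 1 and to compound 2 is in each case beyond the scatter. Compound 3 has a different core from compound 2; how the two cores differ is not broken down here.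

Compound 4, `Nc1ccccc1NC(=O)c1ccc(CSc2ccc(Cl)cc2)cc1`, is not yet measured. It is made from compound 3 by chloro in place of fluoro on an aromatic carbon. Going by the values given here, this is the same change as the one from compound 2 to compound 1: the group that leaves, the group that enters and the place on the ring are described in the same words. Among the compounds with values here, the earlier step was small, so the expectation is a step of a number 1.9 percentage points lower from compound 3 to compound 4 (within the scatter) because the only measured example of this change gave a number 1.1 percentage points higher from compound 2 to compound 1 (within the scatter). That rests on a single pair, measured on a different core, so the expectation is not firm. Compound 4 is therefore estimated to give 80% in this assay, with a range expected from 65% to 92%.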

Compound 4, percent growth inhibition at one concentration: 16.5%
For compound 4 the middle estimate is 63.5 percentage points above the measured one, and the stated range ends above it.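

In this assay, chloro in place of fluoro on an aromatic carbon gave a number 65.4 percentage points lower from compound 3 to compound 4 (beyond the scatter), a large step for a change of a single atom. Set beside the earlier example, the same change did not behave alike on the two cores: the same change on two cores in this assay, a number 1.1 percentage points higher (within the scatter) from compound 2 to compound 1 and a number 65.4 percentage points lower (beyond the scatter) from compound 3 to compound 4, 66.5 percentage points apart, beyond the scatter of two such steps This shows that in this series a step measured on the core of compound 2 cannot simply be carried over to the core of compound 3, but with only one pair on each core it does not show what makes the two cores respond differently, or how the change would behave on any further core.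

The compounds shown leave open whether the drop on the core of compound 3 is specific to chloro, or whether another group in the same place, such as bromo, methyl or methoxy, would give a similar number. They also leave open whether the high number of compound 3 depends on the (4-fluorophenyl)sulfanyl group as a whole, which a version with an ether oxygen in place of the sulfur could begin to test.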